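Carbamate variation at the shared core, phenyl now tested

The compounds below may be only part of what the source reports. "The series", "measured", "known", "first", "only" and "open" are said of these compounds alone.

Compound 1 `CC1(OC(=O)N2CCC(O[C@H]3CC[C@H](Oc4cnc(S(C)(=O)=O)cn4)CC3)CC2)CC1`: 138 nM
Compound 2 `C[C@@H](CF)OC(=O)N1CCC(O[C@H]2CC[C@H](Oc3cnc(S(C)(=O)=O)cn3)CC2)CC1`: 356 nM
Compound 3 `CS(=O)(=O)c1cnc(O[C@H]2CC[C@H](OC3CCN(C(=O)OC4CCOC4)CC3)CC2)cn1`: 1500 nM

In a functional assay on isolated protein for agonist activity at Glucose-dependent insulinotropic receptor (Rattus norvegicus), read by HTRF and cAMP accumulation (a higher number here means that more compound is needed for the effect, a lower number that less compound is needed), compound 3 gives the highest number of the three, with a 4.2-fold higher number from compound 2 to compound 3 (0.62 log units; beyond the scatter) and an 11-fold higher number from compound 1 to compound 3 (1.04 log units; beyond the scatter) both beyond the scatter. Compound 4 `CS(=O)(=O)c1cnc(O[C@H]2CC[C@H](OC3CCN(C(=O)Oc4ccccc4)CC3)CC2)cn1` carries the change (phenyl in place of oxolan-3-yl on an oxygen next to a carbonyl group). All three measured steps, a 2.6-fold higher number from compound 1 to compound 2 (0.41 log units; beyond the scatter), an 11-fold higher number from compound 1 to compound 3 (1.04 log units; beyond the scatter) and a 4.2-fold higher number from compound 2 to compound 3 (0.62 log units; beyond the scatter), alter this same position and show that this assay responds to it, yet none introduces an aromatic group, so the direction for compound 4 is uncertain. Since compound 3 sits at the top, the room to rise is wider than to fall; a modest improvement is expected, a 1.9-fold lower number from compound 3 to compound 4 (0.27 log units; within the scatter). Compound 4 is therefore estimated at 800 nM, within 200 nM to 3500 nM.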

Compound 4, half-maximal effective concentration: 71.8 nM
Compound 4: the middle estimate sits 11-fold (1.05 log units) above what was measured, and the stated range ends above it.
By their numbers in this assay, from the lowest: compounds 4 and 1 (each within the scatter of the next); then compound 2; then compound 3.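

Phenyl on an oxygen next to a carbonyl group, the only aromatic group among the four compounds, gives a 21-fold lower number from compound 3 to compound 4 (1.32 log units; beyond the scatter) and a 5.0-fold lower number from compound 2 to compound 4 (0.70 log units; beyond the scatter) in this assay. An aromatic group is therefore compatible with this position, and the step to the non-aromatic 1-methylcyclopropyl, a 1.9-fold lower number from compound 1 to compound 4 (0.28 log units; within the scatter), leaves the two groups indistinguishable. Nothing available gives a reason for the size of these steps. Still open, as far as these compounds go, is whether a benzyl group, a pyridyl ring or a phenyl carrying a methoxy group or fluorine would hold this level or move it further.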